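Swapping Methoxy for Chloro on the Phenyl Ring

The source may hold more compounds than are shown below. What is called first, only, known or untested is meant among the compounds shown, and "the series" means these compounds.

compound 1 `Cc1cc(Nc2cc(N3CCN(C)CC3)nc(Nc3ccc([N+](=O)[O-])cc3)n2)n[nH]1`: 150 nM
compound 2 `COc1cccc(Nc2nc(Nc3cc(C)[nH]n3)cc(N3CCN(C)CC3)n2)c1`: 332 nM

In a functional assay on A-431 cells (Homo sapiens) for antiproliferative activity, read by CCK-8 assay, with a stated time of 72 h (a lower number here means a stronger inhibitor, a higher number a weaker inhibitor), compound 2 gives 332 nM, the higher and so weaker of the two numbers. Compound 3 `Cc1cc(Nc2cc(N3CCN(C)CC3)nc(Nc3cccc(Cl)c3)n2)n[nH]1` has chloro in place of methoxy on an aromatic carbon, meta to a large group (chloro in place of methoxy on an aromatic carbon). Within the data shown here, only one measured step bears on this: 3-methoxyphenyl in place of 4-nitrophenyl gave a 2.2-fold higher number from compound 1 to compound 2 (0.35 log units; beyond the scatter), a modest change. That step involved different groups, so it is only a loose guide. The expected change is small, a 1.3-fold lower number from compound 2 to compound 3 (0.12 log units; within the scatter), and no shift beyond the scatter is expected. Compound 3 is estimated at 250 nM, with an expected range of 100 nM to 600 nM.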

Compound 3, half-maximal inhibitory concentration: 87.5 nM
Compound 3: the middle estimate sits 2.9-fold (0.46 log units) above what was measured; the measured number lies below the stated range.
By their numbers in this assay, from the lowest: compounds 3 and 1 (each within the scatter of the next); then compound 2.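

In this assay, the group at this spot on the phenyl ring matters on its own: chloro in place of methoxy, with nothing else altered, gives a clear gain (a 3.8-fold lower number from compound 2 to compound 3 (0.58 log units; beyond the scatter)). The 3-chlorophenyl and 4-nitrophenyl compounds cannot be told apart (a 1.7-fold lower number from compound 1 to compound 3 (0.23 log units; within the scatter)), so compound 3 and compound 1 share the lowest numbers here. No measurement shown explains why chloro outperforms methoxy. Still open, as far as these compounds go, is whether fluoro, methyl or an amine at this same place would behave like chloro or like methoxy. Also open, from the compounds shown here alone, is whether chloro would keep this number on another ring carbon.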